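From tert-butyl to acetamido on an aromatic carbon

This account rests on a few compounds, and the source may have more. Where it says the series, first, only, none or still open, it means among the compounds named here.

- compound 1 `Fc1ccc(C(c2ccc(F)cc2)C2CCN(CCCOc3ccc(Br)cc3)CC2)cc1` at 1.59 nM
- compound 2 `CC(C)(C)c1ccc(OCCCN2CCC(C(c3ccc(F)cc3)c3ccc(F)cc3)CC2)cc1` at 1 nM

In a functional assay (aorta) with Oryctolagus cuniculus as the target (on this read-out higher numbers stand for weaker binding and lower numbers for tighter binding), compound 2 stands at 1 nM and cannot be ranked against compound 1 on these numbers. Compound 3 `CC(=O)Nc1ccc(OCCCN2CCC(C(c3ccc(F)cc3)c3ccc(F)cc3)CC2)cc1` differs from compound 2 by acetamido in place of tert-butyl on an aromatic carbon with acetamido in place of tert-butyl. Among the compounds with values here, the only measured step is a 1.6-fold lower number from compound 1 to compound 2 (0.20 log units; within the scatter) and it involves bromo and tert-butyl, so acetamido has no measured precedent. A modest move to a higher number in this assay is expected, though it may stay within the scatter. The expected change is a 2.5-fold higher number from compound 2 to compound 3 (0.40 log units; beyond the scatter) on this estimate. For compound 3 the estimated value is 2.5 nM with an expected range of 0.7 nM to 8 nM in this assay.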

Compound 3, dissociation constant: 12.6 nM
Compound 3: the middle estimate sits 5.0-fold (0.70 log units) below what was measured; measured number above the stated range.
By their numbers in this assay, from the lowest: compounds 2 and 1 (each within the scatter of the next); then compound 3.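

In this assay this aromatic carbon does respond to the group it carries: acetamido gives a 13-fold higher number from compound 2 to compound 3 (1.10 log units; beyond the scatter) and a 7.9-fold higher number from compound 1 to compound 3 (0.90 log units; beyond the scatter) while bromo and tert-butyl remain within the scatter of each other. The swap from tert-butyl keeps the same heavy-atom count and brings in a hydrogen-bond donor and acceptor, so size by atom count does not separate these two groups. No supporting data explain the rise.

Going by these compounds, whether the amide hydrogen or the carbonyl tracks with the higher number remains open. Also open, on these data alone, is how a primary amine or a carboxylic acid on this carbon would read.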